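The source may report more compounds than this note shows. Statements on the series, on what has been measured and on what is new or still open speak of the compounds shown alone.

In an in vitro ADME assay on microsomes (Rattus norvegicus) for metabolic stability (on this read-out lower numbers stand for a shorter-lived compound and higher numbers for a longer-lived compound), compound 1 (`Cc1c2c(n3c1CCN(C(=O)CN)C[C@@H](C)[C@H](C)Nc1cc-3ccc1C(N)=O)CC(C)(C)CC2=O`) gives > 0.5 h, which is a limit of the assay and not a number. Compound 2 (`Cc1c2c(n3c1CCN(C(=O)C(C)(C)N)C[C@@H](C)[C@H](C)Nc1cc-3ccc1C(N)=O)CC(C)(C)CC2=O`) also stands only at a limit, > 0.5 h. Compound 3 (`Cc1c2c(n3c1CCN(C(=O)[C@H](C)O)C[C@@H](C)[C@H](C)Nc1cc-3ccc1C(N)=O)CC(C)(C)CC2=O`) follows from compound 2 by 1-hydroxyethyl in place of 1-amino-1-methylethyl on a carbonyl carbon, with 1-hydroxyethyl in place of 1-amino-1-methylethyl on a carbonyl carbon. Among the compounds with values here, the only measured step that bears on this is a step that the two limits leave unreadable from compound 1 to compound 2, and the limit of > 0.5 h in this assay, at which 2 of the 2 values shown sit, gives no size to carry over. No shift beyond the scatter is therefore expected in this assay, in either direction, and the expected step is a step that the limit leaves unreadable from compound 2 to compound 3. The estimate for compound 3 is 0.6 h, with an expected range from 0.25 h to 1.5 h.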

Compound 3, half-life: 0.483 h
For compound 3 the middle estimate is 1.2-fold (0.09 log units) above the measured one, and the stated range covers the measured number.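

In this assay, within the data shown here, compound 3 gives 0.483 h, the first true number for a group on this carbonyl carbon. 1-Hydroxyethyl in place of 1-amino-1-methylethyl gives an at least 1.0-fold lower number from compound 2 to compound 3 (0.01 log units; that floor lies within the scatter), and 1-hydroxyethyl in place of aminomethyl gives an at least 1.0-fold lower number from compound 1 to compound 3 (0.01 log units; that floor lies within the scatter). Both steps are floors only, because the two amino compounds stand at a limit of the assay: the limit of > 0.5 h in this assay, at which 2 of the 3 values shown sit.

The step between the two amino compounds cannot be read. Going by these compounds, how a carboxylic acid or a longer chain on this carbonyl carbon would stand in this assay remains open.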